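This account rests on a few compounds, and the source may have more. Where it says the series, first, only, none or still open, it means among the compounds named here.

Working notes on the series. Among the measured compounds shown here, two compounds have numbers so far in a physicochemical assay for lipophilicity (a higher number here means a more lipophilic compound, a lower number a more polar compound), and they differ in more than one place, so no single-change step is available. Compound 2 `CN(C)c1ccc(/C=C/C(=O)/C=C/c2ccc(OCCOCCOCCF)cc2)cc1` reads 2.97 and holds the lower of the two numbers. Its nearest neighbour, compound 1 `CNc1ccc(/C=C/C(=O)/C=C/c2ccc(I)cc2)cc1`, reads 3.55 and stands higher by more than the scatter.

Next comes compound 3 `CNc1ccc(/C=C/C(=O)/C=C/c2ccc(OCCOCCOCCF)cc2)cc1`, which keeps everything of compound 2 except the amine: hydrogen in place of methyl on a nitrogen on an aromatic ring (hydrogen in place of methyl on a nitrogen on an aromatic ring, dimethylamino to methylamino). Compound 1 already carries methylamino, but its gap to compound 2 does not measure this change, as the two also differ elsewhere.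

The expectation therefore starts from compound 2 at 2.97 and from the single methyl that leaves. The expected change in this assay is a number 0.25 log units lower from compound 2 to compound 3 (within the scatter) and points downward, a small step close to the scatter. The estimate for compound 3 is 2.72 (expected range 2.35 to 3.05).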

Compound 3, distribution coefficient: 3.08
Estimate against measurement, compound 3: 0.36 log units below; the whole stated range lies below it.
By their numbers in this assay, from the lowest: compounds 2 and 3 (each within the scatter of the next); then compound 1.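

In this assay the amine position now has a single-change reading: a number 0.11 log units higher from compound 2 to compound 3 (within the scatter), so with the 2-(2-(2-fluoroethoxy)ethoxy)ethoxy group held constant, dimethylamino and methylamino on this aromatic nitrogen cannot be told apart. Compound 3 also gives the series a second single-change step, with methylamino held constant and 2-(2-(2-fluoroethoxy)ethoxy)ethoxy in place of iodo on an aromatic carbon: a number 0.47 log units lower from compound 1 to compound 3 (beyond the scatter), a modest step and the only one here beyond the scatter. Nothing available bears on why either step has the size it has.

Going by these compounds, the amine step is read only with the 2-(2-(2-fluoroethoxy)ethoxy)ethoxy group in place, so it remains open whether it would stay within the scatter with iodo on the aromatic carbon, or whether a primary amine, with both methyl groups replaced by hydrogen, would read the same way. The step from iodo likewise rests on a single pair, which leaves open where bromo, or a 2-fluoroethoxy group with a shorter chain, would stand against compound 1 and compound 3.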